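Amide aryl swap in a flavonol series

The compounds below may be only part of what the source reports. "The series", "measured", "known", "first", "only" and "open" are said of these compounds alone.

Measured compounds:
compound 1 `Cc1cccc(C(=O)Nc2cccc(-c3oc4cc(-c5ccc(F)cc5)ccc4c(=O)c3O)c2)c1` — 7850 nM
compound 2 `Cc1cc(C)cc(C(=O)Nc2cccc(-c3oc4cc(-c5ccc(F)cc5)ccc4c(=O)c3O)c2)c1` — 20400 nM

Compound 2 gives the higher of the two numbers in a functional assay on MCF7 cells (Homo sapiens) for antiproliferative activity, read by CCK-8 assay, with a stated time of 72 h (on this read-out higher numbers stand for weaker inhibition and lower numbers for stronger inhibition), the step of a 2.6-fold higher number from compound 1 to compound 2 (0.41 log units; beyond the scatter) standing beyond the scatter. Compound 3 `O=C(Nc1cccc(-c2oc3cc(-c4ccc(F)cc4)ccc3c(=O)c2O)c1)c1ccc(Cl)nc1` carries 6-chloropyridin-3-yl in place of 3,5-dimethylphenyl on a carbonyl carbon. Within the data shown here, no measured step covers this change; the one known step shows only that adding a methyl raised the number, so returning to a ring without methyls, here with a ring nitrogen and chlorine, is expected to move the number back toward that of compound 1. The estimated step is a 2.9-fold lower number from compound 2 to compound 3 (0.46 log units; beyond the scatter), with the likely value for compound 3 at 7000 nM, in a range from 2500 nM to 20000 nM.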

Compound 3, half-maximal inhibitory concentration: 2890 nM
For compound 3 the middle estimate is 2.4-fold (0.38 log units) above the measured one; measured number inside the range.
By their numbers in this assay, from the lowest: compound 3; then compound 1; then compound 2.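

In this assay the group on the carbonyl carbon can lower the number as well as raise it: 6-chloropyridin-3-yl in place of 3,5-dimethylphenyl gives a 7.1-fold lower number from compound 2 to compound 3 (0.85 log units; beyond the scatter) and in place of 3-methylphenyl gives a 2.7-fold lower number from compound 1 to compound 3 (0.43 log units; beyond the scatter). Compound 3, with a ring hetero atom and a chlorine, thus has the lowest number of the three, beyond the scatter from both others. Nothing available explains these steps.

Ring nitrogen, chlorine and the loss of methyl change together here, so their shares cannot be separated. Going by these compounds, whether an amine or a methoxy group in place of the chlorine would hold the number remains open.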